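A chloro added to the terminal urea aryl ring

A few compounds are considered here, and "the series" means these few. Any claim that something is new, unique, unknown or untested is made for them only; others in the source may bear on it.

Compound 1 `O=C(Nc1cccc(-n2cc(-c3ccncc3)c(-c3ccc(Cl)c(O)c3)n2)c1)Nc1cccc(C(F)(F)F)c1`: 2120 nM
Compound 2 `COc1cc(-c2nn(-c3cccc(NC(=O)c4cccc(C(F)(F)F)c4)c3)cc2-c2ccncc2)ccc1Cl`: 3240 nM
Compound 3 `COc1cc(-c2nn(-c3cccc(NC(=O)Nc4cccc(C(F)(F)F)c4)c3)cc2-c2ccncc2)ccc1Cl`: 1310 nM

In a functional assay on TK-10 cells (Homo sapiens) for inhibition, read by sulforhodamine B assay, with a stated time of 48 h (a higher number here means a weaker inhibitor of growth, a lower number a stronger inhibitor of growth), compound 3 gives 1310 nM, the lowest of the three numbers. The nearest is compound 1 at 2120 nM, a gap that is within the scatter (a 1.6-fold lower number from compound 1 to compound 3 (0.21 log units; within the scatter)). The furthest is compound 2 at 3240 nM, a modest gap beyond the scatter (a 2.5-fold lower number from compound 2 to compound 3 (0.39 log units; beyond the scatter)).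

Compound 4 `COc1cc(-c2nn(-c3cccc(NC(=O)Nc4ccc(Cl)c(C(F)(F)F)c4)c3)cc2-c2ccncc2)ccc1Cl` differs from compound 3 by chloro in place of hydrogen on an aromatic carbon. Neither measured step touches this part of the molecule: the step from compound 1 to compound 3 concerns the methyl on an oxygen of the shared core, and the step from compound 2 to compound 3 concerns the linker between the two aryl rings. Among the compounds with values here, no measured pair shows what a chloro on the (3-(trifluoromethyl)phenyl)amino group does in this assay.

Within the data shown here, with no bearing step, the expectation is a step of about a 1.2-fold lower number from compound 3 to compound 4 (0.08 log units; within the scatter), not beyond the scatter. Compound 4 is therefore estimated at 1100 nM, with a range of 400 nM to 3200 nM.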

Compound 4, concentration for 50% growth inhibition: 1520 nM
Estimate against measurement, compound 4: 1.4-fold (0.14 log units) below, and the stated range covers the measured number.
By their numbers in this assay, from the lowest: compounds 3, 4, 1 and 2 (each within the scatter of the next, the first and the last beyond it).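

Within the data shown here, on the aromatic carbon ortho to the trifluoromethyl group, this is the first measured change to the (3-(trifluoromethyl)phenyl)amino group, and in this assay chloro in place of hydrogen gives a 1.2-fold higher number from compound 3 to compound 4 (0.06 log units; within the scatter). This position therefore accepts a chloro with no change that can be told from the scatter, and the (4-chloro-3-(trifluoromethyl)phenyl)amino group keeps the modest separation from the amide compound 2, with a 2.1-fold lower number from compound 2 to compound 4 (0.33 log units; beyond the scatter). Nothing available explains why the chloro leaves the number within the scatter.

The compounds shown leave open whether an amine, a carboxylic acid or a methoxy group on this same carbon would shift the number beyond the scatter. They also leave open whether the chloro would behave alike on compound 1 or compound 2.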